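This account rests on a few compounds, and the source may have more. Where it says the series, first, only, none or still open, it means among the compounds named here.

Measured compounds in a functional assay on DLD-1 cells (Homo sapiens) for antiproliferative activity, read by CellTiter-Glo, with a stated time of 72 h; a lower number here means a stronger inhibitor, a higher number a weaker inhibitor:
compound 1 `Cc1c(C)c(S(=O)(=O)N2CCC(N3CCC(C)CC3)CC2)c(C)c2c1OC(C)(C)C2` gives 1.2 nM
compound 2 `CC1CCN(C2CCN(S(=O)(=O)c3cccnc3)CC2)CC1` gives 2400 nM
compound 3 `Cc1cc(C)c(S(=O)(=O)N2CCC(N3CCC(CCO)CC3)CC2)c(C)c1` gives 19 nM

Among these three, compound 2 stands at the highest number, which here means the weakest inhibition. Its nearest neighbour is compound 3, and the gap between them is well beyond the usual scatter; the gap to compound 1 is wider still. Compound 4 `Cc1cccc(S(=O)(=O)N2CCC(N3CCC(C)CC3)CC2)c1` differs from compound 2 in one place only: 3-methylphenyl in place of pyridin-3-yl on a sulfonyl sulfur. For the measured compounds named here, no pair of measured compounds differs by exactly this change, so no directly measured step exists for it. What the numbers do show is that neither compound 1 nor compound 3 carries the pyridin-3-yl found in compound 2, and both sit at far lower numbers than compound 2, although each of them also differs from compound 2 at other places, so their values cannot be read as a clean test of this one change. On that basis the step from compound 2 to compound 4 is expected to be a large move toward lower numbers, a 12-fold lower number from compound 2 to compound 4 (1.08 log units; beyond the scatter). Compound 4 is estimated at 200 nM, with a likely range from 40 nM to 1000 nM.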

Compound 4, half-maximal inhibitory concentration: 25 nM
Compound 4: the middle estimate sits 8.0-fold (0.90 log units) above what was measured; the measured number lies below the stated range.
By their numbers in this assay, from the lowest: compound 1; then compounds 3 and 4 (each within the scatter of the next); then compound 2.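

Changing pyridin-3-yl to 3-methylphenyl on the sulfonyl sulfur, with the rest of the molecule left as it was, can now be read directly in this assay as a 96-fold lower number from compound 2 to compound 4 (1.98 log units; beyond the scatter), a large step beyond the usual scatter. For the compounds shown here, compound 1 and compound 3 differ from compound 2 in other places as well, so only this pair ties a large shift to the group on the sulfonyl sulfur alone. The swap removes the ring nitrogen and adds a methyl group at once, and nothing shown explains the size of the step.

The compounds shown leave open which of those two parts of the change matters more, a question that a plain phenyl group on the same sulfur could help to settle. They also leave open how far this position tolerates other groups, such as a chlorine or methoxy group on the ring, or an amine or carboxylic acid in place of the methyl group.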